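The source may report more compounds than this note shows. Statements on the series, on what has been measured and on what is new or still open speak of the compounds shown alone.

Three compounds share one core and differ only in the group on a saturated chain carbon bound to a saturated ring carbon. Compound 1 `CC(=O)OC[C@H]1CN(c2ccc(-n3cc(-c4ccccn4)cn3)c(F)c2)C(=O)O1` carries acetoxy there, and in a physicochemical assay for solubility, read by HPLC, with a stated time of 24 h (a lower number here means a less soluble compound, a higher number a more soluble compound), compound 1 gives 373000 nM. Compound 2 `O=C1O[C@@H](CSc2cccs2)CN1c1ccc(-n2cc(-c3ccccn3)cn2)c(F)c1` carries (thiophen-2-yl)sulfanyl, and in this assay compound 2 gives 8500 nM. Compound 3 `CCC(=O)NC[C@H]1CN(c2ccc(-n3cc(-c4ccccn4)cn3)c(F)c2)C(=O)O1` carries propanoylamino, and in this assay compound 3 gives 147000 nM. Compound 3 thus stands second highest of the three: its nearest neighbour is compound 1, separated by a 2.5-fold lower number from compound 1 to compound 3 (0.40 log units; beyond the scatter), while a 44-fold lower number from compound 1 to compound 2 (1.64 log units; beyond the scatter) and a 17-fold higher number from compound 2 to compound 3 (1.24 log units; beyond the scatter) leave compound 2 far below both.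

Compound 4 `CCNC(=O)NC[C@H]1CN(c2ccc(-n3cc(-c4ccccn4)cn3)c(F)c2)C(=O)O1` has not yet been measured. It differs from compound 3 by ethylamino in place of ethyl on a carbonyl carbon. Going by the values given here, none of the measured steps alters this carbonyl carbon; the closest comparison is the exchange of acetoxy for propanoylamino, which gave a 2.5-fold lower number from compound 1 to compound 3 (0.40 log units; beyond the scatter), a modest shift next to the large ones involving compound 2. On that basis the step from compound 3 to compound 4 is expected to be small, a 1.2-fold lower number from compound 3 to compound 4 (0.09 log units; within the scatter), at most modest and possibly within the scatter, with a slight lean toward a lower number. Compound 4 is therefore estimated at 120000 nM, within a range from 50000 nM to 300000 nM.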

Compound 4, solubility: 222000 nM
Compound 4: middle estimate off by 1.9-fold (0.27 log units), on the low side, and the stated range covers the measured number.
By their numbers in this assay, from the lowest: compound 2; then compounds 3, 4 and 1 (each within the scatter of the next, the first and the last beyond it).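

In this assay, ethylamino in place of ethyl on a carbonyl carbon, which turns propanoylamino into (ethylcarbamoyl)amino, gives a 1.5-fold higher number from compound 3 to compound 4 (0.18 log units; within the scatter), so this change at the carbonyl carbon, the first shown there, adds one nitrogen and one hydrogen-bond donor without a step beyond the scatter. Going by these compounds alone, the (ethylcarbamoyl)amino group also stays within the scatter of acetoxy, with a 1.7-fold lower number from compound 1 to compound 4 (0.23 log units; within the scatter), although propanoylamino does not, with a 2.5-fold lower number from compound 1 to compound 3 (0.40 log units; beyond the scatter), while the distance from (thiophen-2-yl)sulfanyl is large, with a 26-fold higher number from compound 2 to compound 4 (1.42 log units; beyond the scatter), leaving compound 2 the one compound set far apart from the other three at this position. No measurement is offered here that would account for any of these numbers.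

The compounds shown leave open whether a longer chain such as butyl in place of the ethyl of the ethylamino group, or a dimethylamino group with no amide hydrogen on that carbonyl carbon, would keep the number in the same range. They also leave open whether a phenylsulfanyl or a methylsulfanyl group on the saturated chain carbon would fall as low as the (thiophen-2-yl)sulfanyl group of compound 2, or whether a free amine there would differ from all four.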